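Sulfanyl in Place of Methoxy on the Shared Core

A few compounds are considered here, and "the series" means these few. Any claim that something is new, unique, unknown or untested is made for them only; others in the source may bear on it.

Compound 1 `Cc1nc(N)c2nc(O)n(Cc3ccccc3)c2n1` is the measured anchor in a functional assay (spleen, spleen) for activation, with Mus musculus as the target (a higher number here means that more compound is needed for the effect, a lower number that less compound is needed), where compound 1 gives 1 uM. Compound 2 `COc1nc2c(N)ncnc2n1Cc1ccccc1` reaches only a limit in this assay: compound 2 gives > 10 uM, which is a limit of the assay and not a number (the limit of > 10 uM in this assay, at which 1 of the 2 values shown sits). Compound 3 `Nc1ncnc2c1nc(S)n2Cc1ccccc1` carries sulfanyl in place of methoxy on an aromatic carbon. For the measured compounds named here, no measured pair shows this change, so the expectation rests on compound 1 and compound 2 alone. For compound 3 the expected step is a number no higher from compound 2 to compound 3 (the limit leaves the size open), toward needing less compound. The estimate for compound 3 is 10 uM, with a likely range from 2 uM to 30 uM.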

Compound 3, minimum effective concentration: 10 uM
Estimate against measurement, compound 3: no gap at the digits printed; the measured number falls inside the stated range.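

In this assay, sulfanyl in place of methoxy on this aromatic carbon between two ring nitrogen atoms gives a number no higher from compound 2 to compound 3 (the limit leaves the size open). Compound 3 thereby gives this position a readable number, 10 uM, which compound 2 did not provide. The size of the step cannot be read because compound 2 stands at a limit of the assay: the limit of > 10 uM in this assay, at which 1 of the 3 values shown sits.

Compound 1 differs from compound 3 in more than one place, so it cannot be compared directly. From the compounds shown here alone, whether an amine or a longer chain such as ethoxy at this position would need less compound remains open.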